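Drawing one stereocentre of compound 3 as S

A few compounds are considered here, and "the series" means these few. Any claim that something is new, unique, unknown or untested is made for them only; others in the source may bear on it.

Compound 1 `CCCN(Cc1ccc(OCCN2C(=O)CCC2=O)c(C)c1)[C@@H](CC(=O)O)c1ccc(Cl)cc1`: 97%
Compound 2 `Cc1cc(CN(CC2CC2)[C@@H](CC(=O)O)c2ccc(Cl)cc2)ccc1OCCN1C(=O)CCC1=O`: 90%
Compound 3 `Cc1cc(CN(CC2CCCC2)C(CC(=O)O)c2ccc(Cl)cc2)ccc1OCCN1C(=O)CCC1=O`: 65%

In an ADME assay on liver (Homo sapiens) for metabolic stability, read by LC-MS, using microsomes and NADPH (a higher number here means that more of the compound is left, a lower number that less of the compound is left), compound 3 gives 65% and holds the lowest of the three numbers, with compound 1 and compound 2 both higher by more than the scatter. Compound 4 `Cc1cc(CN(CC2CCCC2)[C@@H](CC(=O)O)c2ccc(Cl)cc2)ccc1OCCN1C(=O)CCC1=O` has the same atoms and bonds as compound 3, and the two differ only in how one centre is drawn: the two compounds have the same atoms and bonds; at least one stereo element is drawn with a configuration in one of them and without one in the other: 1 of 1 stereo elements differ; a stereocentre at a saturated chain carbon is drawn without a configuration in compound 3 and S in compound 4.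

Among the compounds with values here, only one measured step exists in this small set, and it does not touch that centre. It is a number 7 percentage points lower from compound 1 to compound 2 (within the scatter), a swap of ethyl for cyclopropyl on a saturated chain carbon bound to an amine nitrogen. Within the data shown here, no two measured compounds differ in a stereocentre alone, so the data give no direct measure of what such a change does in this assay. Nothing therefore points to a step in either direction, and the starting point stays with compound 3 (65%). The expected result is a step within the scatter, estimated as a number 3 percentage points higher from compound 3 to compound 4 (within the scatter). Compound 4 is estimated at 68% (52% to 84%).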

Compound 4, percent of the compound remaining: 78%
For compound 4 the middle estimate is 10 percentage points below the measured one; measured number inside the range.
By their numbers in this assay, from the lowest: compound 3; then compound 4; then compounds 2 and 1 (each within the scatter of the next).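

In this assay, the stereocentre at a saturated chain carbon now has a measured step of its own, a number 13 percentage points higher from compound 3 to compound 4 (beyond the scatter), and this step can be tied to that centre alone because nothing else separates the two structures: the fact that one of compounds 3 and 4 is drawn with a defined configuration and the other without, at the place where they differ

Compound 4 also puts a number on cyclopentyl with the centre drawn, and that number sits clearly under both smaller groups, with a number 12 percentage points lower from compound 2 to compound 4 (beyond the scatter) and a number 19 percentage points lower from compound 1 to compound 4 (beyond the scatter). The earlier swap of ethyl for cyclopropyl gave only a number 7 percentage points lower from compound 1 to compound 2 (within the scatter), so the substituent on this carbon shows a step beyond the scatter only once it reaches cyclopentyl.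

The compounds shown leave open how the R configuration at this centre would stand, and so whether the S drawing is the better of the two or only better than the undefined drawing of compound 3. They also leave open whether the lower number seen with cyclopentyl would continue with a cyclohexyl group on the same saturated chain carbon, or would change with a hydroxyl group on the cyclopentyl ring.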